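This account rests on a few compounds, and the source may have more. Where it says the series, first, only, none or still open, it means among the compounds named here.

Compound 1 `Cc1cc(C)c(S(=O)(=O)N2CCC(N3CCC(C(C)C)CC3)CC2)c(C)c1`: in a functional assay on DLD-1 cells (Homo sapiens) for antiproliferative activity, read by CellTiter-Glo, with a stated time of 72 h (a higher number here means a weaker inhibitor, a lower number a stronger inhibitor), compound 1 gives 0.3 nM.
Compound 2 `Cc1cc(C)c(S(=O)(=O)N2CCC(N3CCC(C)OC3)CC2)c(C)c1`: in this assay compound 2 gives 92 nM.
Compound 3 `CC1CCN(C2CCN(S(=O)(=O)c3ccc(Cl)c4ccccc34)CC2)CC1`: in this assay compound 3 gives 0.1 nM.

Compound 2 holds the highest number of the three, far from compound 1 and further still from compound 3. Compound 4 `CCCC(=O)NC1CCN(S(=O)(=O)c2c(C)cc(C)cc2C)CC1` differs from compound 2 in one place: a group of 6 heavy atoms (4 carbon, 1 nitrogen, 1 oxygen; no ring) in place of a group of 7 heavy atoms (5 carbon, 1 nitrogen, 1 oxygen; one six-membered non-aromatic ring with 2 hetero atoms), on a saturated ring carbon. Among the measured compounds shown here, only one measured step touches this part of the core, a 310-fold higher number from compound 1 to compound 2 (2.49 log units; beyond the scatter), and it concerns a different pair of groups on the same saturated ring carbon, so it shows only that this position tolerates change poorly. On that evidence a further weakening is expected from compound 2 to compound 4, a 13-fold higher number from compound 2 to compound 4 (1.12 log units; beyond the scatter). Compound 4 is therefore estimated at 1200 nM, within 200 nM to 10000 nM.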

Compound 4, half-maximal inhibitory concentration: > 5000 nM
Compound 4 was reported as a limit; the forecaster's own chance of this, stated with the estimate: 25%; middle value at least 4.1-fold (0.61 log units) from the limit.
By their numbers in this assay, from the lowest: compound 3; then compound 1; then compound 2. At a limit, above all of these: compound 4.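

The reading for compound 4 is a limit and not a number: the limit of > 5000 nM in this assay, at which 1 of the 4 values shown sits. Putting (propylcarbonyl)amino on this saturated ring carbon gives an at least 54-fold higher number from compound 2 to compound 4 (1.73 log units; beyond the scatter) and an at least 16000-fold higher number from compound 1 to compound 4 (4.22 log units; beyond the scatter). The earlier step therefore did not mark the full loss at this position: this open-chain group, joined through its nitrogen, sits further from the low numbers than the ring with two hetero atoms. Still open, going by these compounds, is whether a plain amine such as dimethylamino on this carbon would restore activity, and whether a longer chain on the carbonyl would change the reading.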